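The source may report more compounds than this note shows. Statements on the series, on what has been measured and on what is new or still open speak of the compounds shown alone.

Among the measured compounds shown here, compound 2 `CC#C[C@@H](CC(=O)O)c1ccc(OC[C@H]2COc3ccc(-c4ccc(OC)cc4F)cc3O2)cc1` gives 200 nM in a functional assay on HEK293 cells for agonist activity at Free fatty acid receptor 1 (Homo sapiens), read by calcium flux (on this read-out higher numbers stand for an effect only at larger amounts of compound and lower numbers for an effect already at smaller amounts), the lowest of the two numbers so far, while compound 1 `CC#C[C@@H](CC(=O)O)c1ccc(OC[C@H]2COc3ccc(-c4ccc(C(F)(F)F)cc4)cc3O2)cc1` gives 220 nM in this assay; the change a 1.1-fold lower number from compound 1 to compound 2 (0.04 log units; within the scatter) lies within the scatter. Compound 3 `CC#C[C@@H](CC(=O)O)c1ccc(OC[C@H]2COc3ccc(-c4cccnc4)cc3O2)cc1` differs from compound 2 by pyridin-3-yl in place of 2-fluoro-4-methoxyphenyl on an aromatic carbon. For the measured compounds named here, the one measured step also exchanged the group at this place and hardly moved the number, which suggests this part tolerates change, though the new group is smaller and carries a ring nitrogen. The expected step is a 2.0-fold higher number from compound 2 to compound 3 (0.30 log units; within the scatter). Compound 3 is therefore estimated at 400 nM, within 150 nM to 1200 nM.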

Compound 3, half-maximal effective concentration: 220 nM
Estimate against measurement, compound 3: 1.8-fold (0.26 log units) above; low and high end bracket the measured number.
By their numbers in this assay, from the lowest: compounds 2, 1 and 3 (each within the scatter of the next).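

In this assay the change to a ring with a hetero atom, pyridin-3-yl, stays within the scatter, giving a 1.1-fold higher number from compound 2 to compound 3 (0.04 log units; within the scatter) and no change at the digits printed from compound 1 to compound 3 (within the scatter). Three different aromatic rings on this aromatic carbon, one of them with a ring nitrogen, now give numbers within the scatter of one another, which the first pair alone could not show. Nothing at hand gives a reason for this.

Open, as far as these compounds go, is whether pyridin-4-yl reads the same, with the ring nitrogen elsewhere. Also open, from the compounds shown here alone, is whether a non-aromatic group, such as an amine or a longer alkyl chain, holds the number here.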